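This account rests on a few compounds, and the source may have more. Where it says the series, first, only, none or still open, it means among the compounds named here.

Compound 1 `CC(C)c1ccc(-c2nc(SCc3cn(CC(=O)NC(=O)Nc4ccccn4)nn3)nc(Nc3ccccc3)c2C#N)cc1` gives in a functional assay on MCF7 cells (Homo sapiens) for inhibition, read by MTT assay, with a stated time of 72 h (a lower number here means a stronger inhibitor, a higher number a weaker inhibitor), only a limit, > 64000 nM.
Compound 2 `CC(C)c1ccc(Nc2nc(SCc3cn(CC(=O)NC(=O)Nc4ccccn4)nn3)nc(-c3ccc(C(C)C)cc3)c2C#N)cc1` gives in this assay 28600 nM.
Compound 3 `COc1cc(-c2nc(SCc3cn(CC(=O)NC(=O)Nc4ccccn4)nn3)nc(Nc3ccc(C(C)C)cc3)c2C#N)cc(OC)c1OC` gives in this assay 30900 nM.

Compound 3 and compound 2 sit within the scatter of each other, the step being a 1.1-fold higher number from compound 2 to compound 3 (0.03 log units; within the scatter). Compound 1 stands at a limit of the assay, as noted in the limit of > 64000 nM in this assay, at which 1 of the 3 values shown sits, so its distance from compound 3 is known only as a lower bound.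

Compound 4 `COc1cc(-c2nc(SCc3cn(CC(=O)NC(=O)Nc4ccccn4)nn3)nc(Nc3cccc(Cl)c3)c2C#N)cc(OC)c1OC` differs from compound 3 in one place: 3-chlorophenyl in place of 4-isopropylphenyl on a nitrogen on an aromatic ring. Two measured steps are relevant. The step of an at least 2.2-fold lower number from compound 1 to compound 2 (0.34 log units; beyond the scatter) shows that an isopropyl group on the anilino ring, where compound 1 has hydrogen, lowers the number at least modestly. The step of a 1.1-fold higher number from compound 2 to compound 3 (0.03 log units; within the scatter), which changes the other aryl group, stays within the scatter. Among the compounds with values here, compound 4 removes the isopropyl from the anilino ring and puts a chlorine elsewhere on that ring; there is no measured pair with a chlorine, so the nearest guide is the loss of the isopropyl, which points towards a higher number.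

Compound 4 is therefore expected to give a weaker result, with an estimated step of a 1.5-fold higher number from compound 3 to compound 4 (0.16 log units; within the scatter). The expected value for compound 4 in this assay is 45000 nM, with a range from 20000 nM to 100000 nM.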

Compound 4, half-maximal inhibitory concentration: 24000 nM
Estimate against measurement, compound 4: 1.9-fold (0.27 log units) above, within the range that was stated.
By their numbers in this assay, from the lowest: compounds 4, 2 and 3 (each within the scatter of the next). At a limit, above all of these: compound 1.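

In this assay, putting 3-chlorophenyl where 4-isopropylphenyl stood, on a nitrogen on an aromatic ring, gives a 1.3-fold lower number from compound 3 to compound 4 (0.11 log units; within the scatter), so compound 3 and compound 4 cannot be told apart and this position accepts the exchange. Within the data shown here, the earlier step, an at least 2.2-fold lower number from compound 1 to compound 2 (0.34 log units; beyond the scatter), made the isopropyl group look like a requirement on this ring, but compound 4 has no isopropyl group and still sits within the scatter of compound 3, so a ring carrying isopropyl is not the only one compatible with a value in this range. The data shown offer no measured property that could explain why these two groups give such similar numbers.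

The isopropyl group and the chlorine differ both in kind and in where they sit on the ring, so the compounds shown cannot separate those two features of the change. Going by these compounds, it also remains open whether a different group on this ring, such as an amine or a carboxylic acid, would move the number beyond the scatter in either direction.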